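This account rests on a few compounds, and the source may have more. Where it says the series, first, only, none or still open, it means among the compounds named here.

Compound 1 `CCCS(=O)(=O)N1CCC(CNC(=O)c2c(F)cccc2F)(C(=O)N2CCOCC2)CC1` gives 131 nM in an assay on isolated protein for inhibition of sodium- and chloride-dependent glycine transporter 1 (Homo sapiens); a lower number here means a stronger inhibitor, a higher number a weaker inhibitor.
Compound 2 `CCCS(=O)(=O)N1CCC(CNC(=O)c2c(F)ccc(Cl)c2F)(C(=O)N2CCOCC2)CC1` gives 8.4 nM in this assay.

Among the compounds with values here, compound 2 stands at the lower of the two numbers in this assay; the single measured step, a 16-fold lower number from compound 1 to compound 2 (1.19 log units; beyond the scatter), separates them and lies beyond the scatter. Compound 3 `CCCS(=O)(=O)N1CCC(CNC(=O)c2ccccc2Cl)(C(=O)N2CCOCC2)CC1` carries the change (2-chlorophenyl in place of 3-chloro-2,6-difluorophenyl on a carbonyl carbon). This undoes that step and goes further: the chloro on an aromatic carbon that set compound 2 apart from compound 1 is no longer present, both fluorines are removed, and a chloro enters within the 2-chlorophenyl instead. Within the data shown here, only the step from compound 1 to compound 2 bears on this, and it was large. Among the measured compounds shown here, no measured step speaks to the fluorines or to the newly placed chloro. Compound 3 is therefore expected to show a step of a 24-fold higher number from compound 2 to compound 3 (1.38 log units; beyond the scatter), a higher number. Compound 3 is estimated at 200 nM in this assay, with a range from 40 nM to 1000 nM.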

Compound 3, half-maximal inhibitory concentration in the sodium- and chloride-dependent glycine transporter 1 assay: 9.7 nM
Compound 3: middle estimate off by 21-fold (1.31 log units), on the high side, and the stated range ends above it.
By their numbers in the sodium- and chloride-dependent glycine transporter 1 assay, from the lowest: compounds 2 and 3 (each within the scatter of the next); then compound 1.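

The fluorines and the chloro of compound 2 turn out not to be required together on this carbonyl carbon, since the sodium- and chloride-dependent glycine transporter 1 assay does not separate the two aryl groups, with a 1.2-fold higher number from compound 2 to compound 3 (0.06 log units; within the scatter) as the step. Set against the unchlorinated difluoro compound, 2-chlorophenyl in place of 2,6-difluorophenyl gives a 14-fold lower number from compound 1 to compound 3 (1.13 log units; beyond the scatter) as its step, so a ring bearing one chloro and no fluorine reaches the same level as the 3-chloro-2,6-difluorophenyl group. In a physicochemical assay for lipophilicity (a higher number here means a more lipophilic compound, a lower number a more polar compound), compound 2 gives < 1.4, which is a limit of the assay and not a number. In the physicochemical assay compound 3 gives < 1.4, which is likewise a limit of the assay and not a number. The step between these two compounds therefore cannot be read: the limit of < 1.4 in the physicochemical assay, at which 2 of the 2 values shown sit.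

The compounds shown leave open whether a methyl, a methoxy or a trifluoromethyl group could stand in for the chloro of the 2-chlorophenyl group and hold this level in the sodium- and chloride-dependent glycine transporter 1 assay as well. They also leave open what a pyridine ring would do in place of the phenyl ring.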